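Cyanomethyl-pyrazole series: methoxy to hydroxy on the aryl ring

A few compounds are considered here, and "the series" means these few. Any claim that something is new, unique, unknown or untested is made for them only; others in the source may bear on it.

Measured so far in a functional assay on KM12 cells (Homo sapiens) for inhibition, read by sulforhodamine B assay, with a stated time of 48 h; on this read-out lower numbers stand for higher toxicity in this test and higher numbers for lower toxicity in this test:
compound 1 `COc1cc(C)cc(-c2nn(CC#N)cc2-c2ccc(-c3cccc(C(C)=O)c3)nc2)c1`: > 100000 nM, a limit of the assay, not a number
compound 2 `Cc1cc(O)cc(-c2nn(CC#N)cc2-c2ccnc(-c3ccc(Oc4ccccc4)cc3)c2)c1`: 15300 nM
compound 3 `COc1cc(C)cc(-c2nn(CC#N)cc2-c2ccnc(-c3ccc(N(C)C)cc3)c2)c1`: 25500 nM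

Compound 1 gives only a limit in this assay, as noted in the limit of > 100000 nM in this assay, at which 1 of the 3 values shown sits. Of the two numbers in hand, compound 3 carries the higher one, but its nearest neighbour compound 2 lies within the scatter of it, so nothing separates them.

Compound 4 `Cc1cc(O)cc(-c2nn(CC#N)cc2-c2ccnc(-c3ccc(N(C)C)cc3)c2)c1` has not yet been measured. It differs from compound 3 by hydrogen in place of methyl on an oxygen on an aromatic ring. Among the measured compounds shown here, no measured pair in the set shares this change, so the size of the step is not known. Compound 2 already carries a hydroxy group on the same ring and still sits within the scatter of compound 3, which suggests that this single change may matter little.

Compound 4 is therefore expected to give 20000 nM in this assay, in the range 6000 nM to 70000 nM. The expected step from compound 3 to compound 4 is a 1.3-fold lower number from compound 3 to compound 4 (0.11 log units; within the scatter), not clearly beyond the scatter in either direction.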

Compound 4, concentration lethal to 50% of the cells: 29200 nM
Compound 4: the middle estimate sits 1.5-fold (0.16 log units) below what was measured, and the stated range covers the measured number.
By their numbers in this assay, from the lowest: compounds 2, 3 and 4 (each within the scatter of the next). At a limit, above all of these: compound 1.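

Methoxy to hydroxy on the aromatic ring now has a measured size in this assay: a 1.1-fold higher number from compound 3 to compound 4 (0.06 log units; within the scatter), so with the dimethylamino group in place this change does not separate the two compounds. With the hydroxy group held, dimethylamino in place of phenoxy gives a 1.9-fold higher number from compound 2 to compound 4 (0.28 log units; within the scatter), so the second place of difference does not separate its pair either. Nothing measured here bears on what lies behind these two steps.

Open, going by these compounds, is whether the same holds for a larger group on that oxygen, such as ethoxy or a longer ether chain ending in a carboxylic acid. Also open, on these data alone, is how a primary amine or morpholine would read in place of dimethylamino on the shared core.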